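The compounds below may be only part of what the source reports. "The series", "measured", "known", "first", "only" and "open" are said of these compounds alone.

Working notes on the series.

Compound 1 `Nc1scc(CN2CCN(c3ccc(Cl)cc3Cl)CC2)c1C(=O)c1ccc(Cl)cc1` is the reference point. In an assay on CHO cells for displacement of a labelled ligand from adenosine receptor A1 (Homo sapiens), read by scintillation counting, with a stated time of 120 min, tested at 10 uM (on this read-out lower numbers stand for less inhibition and higher numbers for more inhibition at the one concentration tested (going by the name of the read-out)), compound 1 gives 0%, the lowest of the three numbers in hand, though every neighbour sits within the scatter of it. Compound 2 `Nc1scc(CN2CCN(c3cccc4ccccc34)CC2)c1C(=O)c1ccc(Cl)cc1` gives 1% and compound 3 `Nc1scc(CN2CCN(c3cccc(F)c3)CC2)c1C(=O)c1ccc(Cl)cc1` gives 1%. The two changes made on the amine nitrogen in the ring so far moved the read-out a number 1 percentage points higher from compound 1 to compound 2 (within the scatter) and a number 1 percentage points higher from compound 1 to compound 3 (within the scatter), neither beyond the scatter.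

Compound 4 `Nc1scc(CN2CCN(c3cccc(F)c3F)CC2)c1C(=O)c1ccc(Cl)cc1` carries the change (2,3-difluorophenyl in place of 2,4-dichlorophenyl on an amine nitrogen in a ring). Both earlier steps at this same position bear on it, and both were flat, so no step beyond the scatter is expected here either. Compound 4 is therefore estimated at 1%, range -5% to 9%, an expected step of a number 1 percentage points higher from compound 1 to compound 4 (within the scatter).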

Compound 4, a percentage reported as inhibition, at one concentration (the size of the read-out at that concentration, not a potency): 0%
Beside the measured number, compound 4's estimate is 1 percentage points above it, within the range that was stated.
By their numbers in this assay, from the lowest: compounds 1, 4, 2 and 3 (each within the scatter of the next).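

In this assay, 2,3-difluorophenyl in place of 2,4-dichlorophenyl gives no change at the digits printed from compound 1 to compound 4 (within the scatter) at this position, so exchanging both chlorines for fluorines in a new arrangement leaves the read-out flat. Fluoro in place of hydrogen on an aromatic carbon gives a number 1 percentage points lower from compound 3 to compound 4 (within the scatter) and, with 2,3-difluorophenyl in place of naphthalen-1-yl giving a number 1 percentage points lower from compound 2 to compound 4 (within the scatter) as well, the position still shows no step beyond the scatter. No measurement on hand accounts for this flatness.

As far as these compounds go, whether an amine or a carboxylic acid on this phenyl group, or a benzyl group on the amine nitrogen in a ring, would move the read-out remains open. So does the effect of any change elsewhere on the shared core.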